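Aminopyrimidine series: hydroxybutyl in place of cyclohexyl

The compounds below may be only part of what the source reports. "The series", "measured", "known", "first", "only" and "open" are said of these compounds alone.

Measured so far:
compound 1 `O=C(Nc1ncc(-c2cccc(Cl)c2)c(-c2ccccc2)n1)C1CCCC1`, 47%
compound 2 `C#CCNc1ncc(-c2cccc(Cl)c2)c(-c2ccccc2)n1`, 76%
compound 3 `Clc1cccc(-c2cnc(NC3CCCCC3)nc2-c2ccccc2)c1`, 58%

All three compounds share one core and differ only in the group on a nitrogen on an aromatic ring. In an assay on CHO cells for displacement of a labelled ligand from adenosine receptor A1 (Homo sapiens), read by scintillation counting, with a stated time of 1 h, tested at 1 uM (a higher number here means more inhibition at the concentration tested (going by the name of the read-out), a lower number less inhibition), compound 3 gives 58% and stands second highest of the three numbers; its nearest neighbour is compound 1 at 47%, the furthest is compound 2 at 76%. The steps among them are all modest: a number 29 percentage points higher from compound 1 to compound 2 (beyond the scatter), a number 11 percentage points higher from compound 1 to compound 3 (beyond the scatter), and a number 18 percentage points lower from compound 2 to compound 3 (beyond the scatter).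

Compound 4 `OCCCCNc1ncc(-c2cccc(Cl)c2)c(-c2ccccc2)n1` is not yet measured. Its difference from compound 3 is 4-hydroxybutyl in place of cyclohexyl on a nitrogen on an aromatic ring. Within the data shown here, every measured step bears on it, since each changes the group on the same nitrogen, and none moved the number by more than a modest amount; no measured step introduces a hydroxyl-bearing chain, so the direction is open. A step within or just beyond the scatter is expected. Compound 4 is therefore expected to give about 55%, between 30% and 78%. The expected step is a number 3 percentage points lower from compound 3 to compound 4 (within the scatter).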

Compound 4, a percentage reported as inhibition, at one concentration (the size of the read-out at that concentration, not a potency): > 80%
Compound 4: a limit, no number; the forecaster's own chance of this, stated with the estimate: 0%; middle value at least 25 percentage points away from the limit.
By their numbers in this assay, from the lowest: compound 1; then compound 3; then compound 2. At a limit, above all of these: compound 4.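

In this assay compound 4 gives > 80%, which is a limit of the assay and not a number: the limit of > 80% in this assay, at which 1 of the 4 values shown sits. This nitrogen accepts an open chain ending in a hydroxyl, a feature absent from the earlier groups, and the reading rises with a number at least 22 percentage points higher from compound 3 to compound 4 (beyond the scatter) and with a number at least 33 percentage points higher from compound 1 to compound 4 (beyond the scatter). Against the propargyl group the picture is less clear, with a number at least 4 percentage points higher from compound 2 to compound 4 (that floor lies within the scatter), so the two compounds cannot be ranked on these readings.

On these data alone, because compound 4 sits at a limit, the true size of all three steps remains unknown: the limit of > 80% in this assay, at which 1 of the 4 values shown sits. As far as these compounds go, it also remains open whether the hydroxyl or the open chain drives the rise, and what a 4-aminobutyl group, a carboxylic acid or a shorter hydroxyalkyl chain would give on this nitrogen.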